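Removing one carbon from the oxadiazole tail: expected cytotoxicity

A few compounds are considered here, and "the series" means these few. Any claim that something is new, unique, unknown or untested is made for them only; others in the source may bear on it.

Compound 1 `O=C1N(Cc2cccc(COc3ccc(-c4ccc(Cl)cc4)cc3)c2)CCN1c1ccncc1` and compound 2 `CCc1nc(-c2ccc(OCCC(C)CCN3CCN(c4ccncc4)C3=O)cc2)no1` were both tested in an ADME assay on cells (Homo sapiens) for cytotoxicity; on this read-out higher numbers stand for lower toxicity in this test and lower numbers for higher toxicity in this test. In this assay compound 1 gives > 6250 nM, which is a limit of the assay rather than a number. In the same assay compound 2 gives > 25000 nM, again a limit and not a number. Compound 2 therefore stands at the limit of > 25000 nM in this assay, at which 1 of the 2 values shown sits, while the other compound sits at the limit of > 6250 nM in this assay, at which 1 of the 2 values shown sits, so neither value pins down a real position and nothing can be said about order between them.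

Compound 3 `Cc1nc(-c2ccc(OCCC(C)CCN3CCN(c4ccncc4)C3=O)cc2)no1` has not yet been measured. It differs from compound 2 by hydrogen in place of methyl on a saturated chain carbon bound to an aromatic carbon. The change is small: the oxadiazole ring and the rest of the molecule stay as they are.

Within the data shown here, with no measured pair of neighbours to lean on, and with compound 2 reaching only a limit, the step to compound 3 is expected to be none beyond the usual scatter, an expected step that the limit leaves unreadable from compound 2 to compound 3. Compound 3 is therefore estimated to give about 30000 nM, within a range from 12000 nM to 80000 nM, most likely again reported only as a limit.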

Compound 3, half-maximal cytotoxic concentration: > 6250 nM
Compound 3 was reported as a limit (the forecaster's own chance of this, stated with the estimate: 80%); the middle value does not contradict the limit.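

Compound 2 and compound 3 are each reported only as a limit, not a number, in this assay, so no step can be read between them. The compounds shown leave open whether going from 5-ethyl-1,2,4-oxadiazol-3-yl to 5-methyl-1,2,4-oxadiazol-3-yl changes the read-out at all, and at what concentration any of these compounds reaches the half-maximal cytotoxic effect.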